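This account rests on a few compounds, and the source may have more. Where it says the series, first, only, none or still open, it means among the compounds named here.

Measured so far in a functional assay (spleen, spleen) for activation, with Mus musculus as the target; on this read-out higher numbers stand for an effect only at larger amounts of compound and lower numbers for an effect already at smaller amounts:
compound 1 `COc1cccc(Cn2c(O)nc3c(N)ncnc32)c1` — 10 uM
compound 2 `CCSc1nc(N)c2nc(O)n(Cc3ccccc3)c2n1` — 0.1 uM

Of the two compounds measured in this assay, compound 2 gives the lower number, and compound 1 stands a long way from it, beyond the scatter. The two structures differ in more than one place, so nothing can be read from that pair about any single change; the values simply show that compound 2 acts at a much smaller amount than compound 1.

Compound 3 `COc1nc(N)c2nc(O)n(Cc3ccccc3)c2n1` has not yet been measured in this assay. It comes from compound 2 by one change: methoxy in place of ethylsulfanyl on an aromatic carbon. Among the measured compounds shown here, no measured pair shows what this exchange does, so the expectation rests on compound 2 alone.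

The step expected from compound 2 to compound 3 in this assay is a 3.0-fold higher number from compound 2 to compound 3 (0.48 log units; beyond the scatter), a small move toward a larger minimum effective concentration, not much beyond the scatter. Compound 3 is estimated to come in at 0.3 uM, with a range from 0.05 uM to 3 uM.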

Compound 3, minimum effective concentration: 0.1 uM
Estimate against measurement, compound 3: 3.0-fold (0.48 log units) above; measured number inside the range.
By their numbers in this assay, from the lowest: compounds 2 and 3 (each within the scatter of the next); then compound 1.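

In this assay, putting methoxy in place of ethylsulfanyl on the aromatic carbon between two ring nitrogen atoms gives no change at the digits printed from compound 2 to compound 3 (within the scatter), so the read-out stays within the scatter across this exchange. Among the compounds shown here, this is the first pair that isolates a single change at this position, which the comparison of compound 1 with compound 2 could not do, and it shows that the low number of compound 2 does not depend on the sulfur-containing ethylsulfanyl group, since the smaller methoxy of compound 3 serves as well in this assay. No measurement at hand speaks to what lies behind this similarity.

As far as these compounds go, the two groups compared here are both short chains attached through a single atom, so it remains open whether a longer chain such as butoxy, or an amine such as butylamino, would keep the read-out where it stands. Also open, from the compounds shown here alone, is what a bare hydrogen on this carbon would do on the core of compound 3, which would show whether the position needs a substituent at all.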